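Pyridin-2-yl for pyrazin-2-yl at the solubility limit

This account rests on a few compounds, and the source may have more. Where it says the series, first, only, none or still open, it means among the compounds named here.

In a physicochemical assay for solubility, read by nephelometry, in phosphate buffer, measured as kinetic solubility, at pH 6.5 (on this read-out higher numbers stand for higher solubility and lower numbers for lower solubility), compound 1 `CC(=O)c1ccc(NC(=O)Nc2ccc(F)c(C(F)(F)F)c2)cc1` gives < 1.6 ug/mL as a limit, not a number. Compound 2 `O=C(Nc1ccc(F)c(C(F)(F)F)c1)Nc1cnccn1` likewise gives < 1.6 ug/mL as a limit. The record so far is therefore only the limit of < 1.6 ug/mL in this assay, at which 2 of the 2 values shown sit, and holds no true number. The change pyridin-2-yl in place of pyrazin-2-yl on an amide-type nitrogen leads to compound 3 `O=C(Nc1ccc(F)c(C(F)(F)F)c1)Nc1ccccn1` with pyridin-2-yl in place of pyrazin-2-yl on an amide-type nitrogen. No measured step sizes this change, and nothing beyond the scatter is expected in this assay for the estimated step of a number no lower from compound 2 to compound 3 (the limit leaves the size open) here. Another limit reading is quite possible. Compound 3 is expected at 1.6 ug/mL within an estimated range of 1 ug/mL to 4 ug/mL in this read-out.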

Compound 3, solubility: < 1.6 ug/mL
Compound 3: only a limit was reported; the forecaster's own chance of this, stated with the estimate: 70%; the middle value lies on the limit itself.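

The step from compound 2 to compound 3 cannot be read, because both readings are limits: the limit of < 1.6 ug/mL in this assay, at which 3 of the 3 values shown sit.

The compounds shown leave open where compound 1, compound 2 and compound 3 truly lie, and whether pyridin-2-yl and pyrazin-2-yl differ at all on this read-out.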